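The compounds below may be only part of what the source reports. "The series", "measured", "known", "first", "only" and "open" are said of these compounds alone.

Measured so far in a functional assay on MES-SA cells (Homo sapiens) for inhibition, read by MTT assay, with a stated time of 72 h; on this read-out higher numbers stand for weaker inhibition and lower numbers for stronger inhibition:
- compound 1 `O=[N+]([O-])c1ccc(NC(=S)N/N=C/c2ccccn2)cc1`: 2570 nM; 2700 nM (2 entries)
- compound 2 `Cc1ccc(NC(=S)N/N=C/c2ccccc2O)cc1`: 3970 nM
- compound 3 `COc1cc(N/N=C/c2ccccn2)ncn1`: 2820 nM

Compound 3 gives 2820 nM and its nearest single-value neighbour, compound 2, gives 3970 nM. These two values lie within the scatter of each other, so no order can be drawn between them. Compound 1 has no single number, but its repeat measurements agree closely: the several entries of compound 1 in this assay, 2570 nM; 2700 nM (2 entries). All three compounds therefore sit in the same low micromolar region in this assay.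

Compound 4 `CCc1ccc(/C=N/Nc2cc(OC)ncn2)nc1` is not yet measured. It carries ethyl in place of hydrogen on an aromatic carbon of compound 3, two atoms from the ring nitrogen and para to a large group: ethyl in place of hydrogen on an aromatic carbon.

Among the compounds with values here, no step between measured compounds shows what such a change does, so the expectation starts from compound 3 at 2820 nM. A shift beyond the scatter is not expected, and no direction is favoured strongly, though the range is kept wide on the data available. The expected change is a 1.3-fold lower number from compound 3 to compound 4 (0.11 log units; within the scatter). For compound 4 the estimated value is 2200 nM, with an expected range from 600 nM to 7000 nM.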

Compound 4, half-maximal inhibitory concentration: 1550 nM
For compound 4 the middle estimate is 1.4-fold (0.15 log units) above the measured one; the measured number falls inside the stated range.
By their numbers in this assay, from the lowest: compounds 4, 3 and 2 (each within the scatter of the next, the first and the last beyond it).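

Ethyl in place of hydrogen on an aromatic carbon, two atoms from the ring nitrogen and para to a large group, is the only single-place change available in the series, and in this assay it gives a 1.8-fold lower number from compound 3 to compound 4 (0.26 log units; within the scatter). Within the data shown here, the earlier compounds offered no step at all, so this is the first reading at this position: the ring carbon carries ethyl with no shift beyond the scatter, and neither a gain nor a loss can be claimed from it. The data at hand give no measured property that bears on this step, and no cause can be assigned to it.

Still open, going by these compounds, is whether a longer chain such as butyl, or an amine or a carboxylic acid, on the same aromatic carbon would move the number beyond the scatter, in either direction. Also open, on these data alone, is whether ethyl on another carbon of the same ring would give a step of similar size, or whether the tolerance seen here belongs to this position alone.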